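Furan-2-ylmethyl Amide on the Shared Core: An Expectation

The source may hold more compounds than are shown below. What is called first, only, known or untested is meant among the compounds shown, and "the series" means these compounds.

Measured compounds:
compound 1, `CCCNC(=O)c1cccc2nc(OCC)n(Cc3ccc(-c4ccccc4-c4nnn[nH]4)cc3)c12`: 32.6%
compound 2, `CCOc1nc2cccc(C(=O)Nc3ccccc3)c2n1Cc1ccc(-c2ccccc2-c2nnn[nH]2)cc1`: 34.6%
compound 3, `CCOc1nc2cccc(C(=O)Nc3ccc(F)cc3)c2n1Cc1ccc(-c2ccccc2-c2nnn[nH]2)cc1`: 45.3%

Three compounds share one core and differ only in the group on the amide-type nitrogen. In an assay on isolated protein for inhibition of NEDD8-activating enzyme E1 regulatory subunit (Homo sapiens), read by Western blot, with stated times of 10 min and 30 min, tested at 25 uM (a lower number here means less inhibition, a higher number more inhibition at the concentration tested (going by the name of the read-out)), compound 1 gives 32.6%, compound 2 gives 34.6% and compound 3 gives 45.3%. Compound 1 sits at the low end of the three: the step of a number 2 percentage points higher from compound 1 to compound 2 (within the scatter) is within the scatter, while the step of a number 12.7 percentage points higher from compound 1 to compound 3 (beyond the scatter) is beyond it, as is the step of a number 10.7 percentage points higher from compound 2 to compound 3 (beyond the scatter).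

Compound 4, `CCOc1nc2cccc(C(=O)NCc3ccco3)c2n1Cc1ccc(-c2ccccc2-c2nnn[nH]2)cc1`, differs from compound 1 in one place: furan-2-yl in place of ethyl on a saturated chain carbon bound to an amide-type nitrogen. For the measured compounds named here, only the steps from compound 1 bear on this change, and each of them exchanges the whole propyl for an aromatic group directly on the nitrogen; here the chain is kept and a ring enters one carbon away. Those steps were small to modest, so a step of similar or smaller size is expected in this assay, with no clear direction. Compound 4 is therefore estimated at 36%, between 22% and 50%, which would be a step of a number 3.4 percentage points higher from compound 1 to compound 4 (within the scatter), within the scatter.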

Compound 4, a percentage reported as inhibition, at one concentration (the size of the read-out at that concentration, not a potency): 37.5%
For compound 4 the middle estimate is 1.5 percentage points below the measured one; measured number inside the range.
By their numbers in this assay, from the lowest: compounds 1, 2, 4 and 3 (each within the scatter of the next, the first and the last beyond it).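

In this assay, replacing ethyl with furan-2-yl on the saturated chain carbon bound to the amide-type nitrogen gives a number 4.9 percentage points higher from compound 1 to compound 4 (within the scatter), so this position accepts a five-membered aromatic ring one carbon away from that nitrogen without a shift that can be told from the scatter. Compound 4 also cannot be separated from either compound with a ring directly on the nitrogen, with a number 2.9 percentage points higher from compound 2 to compound 4 (within the scatter) and a number 7.8 percentage points lower from compound 3 to compound 4 (within the scatter), even though those two compounds are themselves separated by a number 10.7 percentage points higher from compound 2 to compound 3 (beyond the scatter). Nothing available accounts for these numbers or links them to any feature of the furan-2-yl group.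

Going by these compounds, it remains open whether a phenyl or a saturated tetrahydrofuran-2-yl ring on the same chain carbon, or a longer chain between the ring and the nitrogen, would move the number beyond the scatter. On these data alone, it is equally open whether the fluoro substitution that separates compound 3 from compound 2 would have any comparable effect on a 4-fluorobenzyl group at this position.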